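The source may hold more compounds than are shown below. What is called first, only, known or untested is meant among the compounds shown, and "the series" means these compounds.

Measured compounds:
compound 1 `CCCCOc1cc(C(=O)NC)nn1-c1ccccc1` — 65%
compound 2 `CCCCOc1cc(C(=O)NCCC)nn1-c1ccccc1` — 51.2%

Of the compounds shown here, two have been measured in a functional assay on the whole organism (strain Wistar) for inhibition, with Rattus norvegicus as the target, read by paw edema, with stated times of 30 min and 3 h, at a dose of 100 mg/kg by the oral route; on this read-out higher numbers stand for more inhibition at the one dose given (going by the name of the read-out) and lower numbers for less inhibition. Compound 1 `CCCCOc1cc(C(=O)NC)nn1-c1ccccc1` gives 65%, and compound 2 `CCCCOc1cc(C(=O)NCCC)nn1-c1ccccc1` gives 51.2%. Among the compounds with values here, the one step between them, a number 13.8 percentage points lower from compound 1 to compound 2 (beyond the scatter), goes with ethyl in place of hydrogen on a saturated chain carbon bound to an amide-type nitrogen. Within the data shown here, compound 2 therefore stands at the lower of the two numbers, with compound 1 as its only neighbour, the gap between them being beyond the scatter.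

The next compound, compound 3 `CCCCOc1cc(C(=O)NCCCN(C)C)nn1-c1ccccc1`, differs from compound 2 by dimethylamino in place of hydrogen on a saturated chain carbon, three bonds along the chain from an amide-type nitrogen. Among the measured compounds shown here, no measured step carries a dimethylamino group, so the only step that bears on a change to this chain is a number 13.8 percentage points lower from compound 1 to compound 2 (beyond the scatter), a modest loss. On that basis a further small decrease, or no step beyond the scatter, is expected in this assay. Compound 3 is expected to give 45%, in a range from 25% to 65%. This estimate means a step of a number 6.2 percentage points lower from compound 2 to compound 3 (within the scatter), expected to be modest at most.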

Compound 3, a percentage reported as inhibition, in the whole organism at one dose (the size of the read-out at that dose, not a potency): 29.8%
Beside the measured number, compound 3's estimate is 15.2 percentage points above it, within the range that was stated.
By their numbers in this assay, from the lowest: compound 3; then compound 2; then compound 1.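

In this assay, dimethylamino in place of hydrogen on a saturated chain carbon, three bonds along the chain from an amide-type nitrogen, goes with a number 21.4 percentage points lower from compound 2 to compound 3 (beyond the scatter), so a change this far along the chain still moves the read-out beyond the scatter. Read against the shortest chain, the same position gives a number 35.2 percentage points lower from compound 1 to compound 3 (beyond the scatter), the only step here classed as large, and among these three compounds both additions to the chain go with a lower number, with no compound going against that trend. Nothing available on these compounds explains why the number falls with these changes.

The three compounds leave open whether the fall follows the dimethylamino group itself or the chain that carries it, a question that a shorter 2-(dimethylamino)ethyl chain on the amide-type nitrogen or a butyl chain without an amine could help to settle. They also leave open how a hydroxyl group, a carboxylic acid or a morpholine ring at the end of the same chain would read out at this one dose.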